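The compounds below may be only part of what the source reports. "The series", "measured", "known", "first", "only" and "open" are said of these compounds alone.

Measured in a functional assay on B16-F10 cells (Mus musculus) for antiproliferative activity, read by CCK-8 assay, with a stated time of 48 h; on this read-out higher numbers stand for weaker inhibition and lower numbers for stronger inhibition:
- compound 1 `COc1ccc(/C=C\c2cc(OC)c(OC)c(OC)c2)cc1OCc1ccc(CN2CCCC[C@@H]2C(=O)O)cc1`: > 10000 nM (a limit)
- compound 2 `COc1ccc(/C=C\c2cc(OC)c(OC)c(OC)c2)cc1OCc1ccc(CN2CCCCC2C(=O)O)cc1`: > 10000 nM (a limit)
- compound 3 `COc1ccc(/C=C\c2cc(OC)c(OC)c(OC)c2)cc1OCc1ccc(CN2CC[C@H](C(=O)O)C2)cc1`: 7000 nM

Compound 2 gives only a limit and stands at the limit of > 10000 nM in this assay, at which 2 of the 3 values shown sit. Any step from it therefore has a loose starting point.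

Compound 4 `COc1ccc(/C=C\c2cc(OC)c(OC)c(OC)c2)cc1OCc1ccc(CNCCNC(C)=O)cc1` carries (2-acetamidoethyl)amino in place of 2-carboxypiperidin-1-yl on a saturated chain carbon bound to an aromatic carbon.

For the measured compounds named here, three measured steps bear on this change, and none gives a firm size. Going by the values given here, the first is a step that the two limits leave unreadable from compound 1 to compound 2, which offers no guide. The other two are an at least 1.4-fold lower number from compound 1 to compound 3 (0.15 log units; that floor lies within the scatter) and an at least 1.4-fold lower number from compound 2 to compound 3 (0.15 log units; that floor lies within the scatter). Both exchange the same group at the same place, but their floors stay within the scatter. Among the compounds with values here, no measured step replaces the ring with an open chain, and none removes the carboxy group, so the change to compound 4 goes beyond what the series has tested.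

Within the data shown here, the only true number is that of compound 3, 7000 nM, and the expectation leans on it. In this assay the expected change is modest and towards a lower number, estimated as an at least 1.6-fold lower number from compound 2 to compound 4 (0.22 log units; that floor lies within the scatter). A result at the limit would not be surprising.

For compound 4 the estimated value is 6000 nM, with an expected range of 1000 nM to 20000 nM.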

Compound 4, half-maximal inhibitory concentration: 2500 nM
Compound 4: the middle estimate sits 2.4-fold (0.38 log units) above what was measured; measured number inside the range.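

In this assay, for the compounds shown here, compound 4 shows that this place, a saturated chain carbon bound to an aromatic carbon, accepts an open chain with no ring and no carboxy group, and the one step here with true numbers at both ends lies beyond the scatter: a 2.8-fold lower number from compound 3 to compound 4 (0.45 log units; beyond the scatter). Going by these compounds alone, the steps of an at least 4.0-fold lower number from compound 2 to compound 4 (0.60 log units; beyond the scatter) and an at least 4.0-fold lower number from compound 1 to compound 4 (0.60 log units; beyond the scatter) also lie beyond the scatter, so the change from the 2-carboxypiperidin-1-yl compounds is now readable in direction, which the earlier steps within the scatter did not allow. Their sizes remain floors only, since the starting values of both are limits: the limit of > 10000 nM in this assay, at which 2 of the 4 values shown sit.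

The change removes the ring and the carboxy group and brings in the acetamide all at once, so the compounds shown do not tell which of these carries the step, and they give no explanation for it. A plain piperidin-1-yl group, an open chain ending in a carboxylic acid, a free primary amine in place of the acetamide, or a longer chain carrying the same acetamide would separate these contributions.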